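A few compounds are considered here, and "the series" means these few. Any claim that something is new, unique, unknown or untested is made for them only; others in the source may bear on it.

Compound 1, `CCc1cc2ccccc2nc1-c1cc(-c2ccccc2)no1`, in a functional assay on COLO 205 cells (Homo sapiens) for inhibition, read by MTT assay, with a stated time of 24 h (a lower number here means a stronger inhibitor, a higher number a weaker inhibitor), gives > 100000 nM, a limit of the assay.
Compound 2, `CCCc1cc2ccccc2nc1-c1cc(-c2ccccc2)no1`, gives 48900 nM.
Compound 3, `CCCCc1cc2ccccc2nc1-c1cc(-c2ccc(C)cc2)no1`, gives > 100000 nM, a limit of the assay.

The step from compound 1 to compound 2 is methyl in place of hydrogen on a saturated chain carbon, two bonds along the chain from an aromatic carbon and reads an at least 2.0-fold lower number from compound 1 to compound 2 (0.31 log units; beyond the scatter). Compound 4, `CCCCCc1cc2ccccc2nc1-c1cc(-c2ccc(C)cc2)no1`, is not yet measured; it differs from compound 3 by methyl in place of hydrogen on a saturated chain carbon, four bonds along the chain from an aromatic carbon, the same kind of change, though the place differs: two bonds along the chain from an aromatic carbon in the first pair, four bonds in the second. The difference between the cores of compound 1 and compound 3 is not broken down here. Since compound 3 sits at the limit of > 100000 nM in this assay, at which 2 of the 3 values shown sit, only a limit is known there, so the step it would make cannot be counted with the same confidence. The expected step from compound 3 to compound 4 is an at least 1.6-fold lower number from compound 3 to compound 4 (0.22 log units; that floor lies within the scatter), resting on an at least 2.0-fold lower number from compound 1 to compound 2 (0.31 log units; beyond the scatter). Compound 4 is expected to give about 60000 nM, between 20000 nM and 200000 nM.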

Compound 4, half-maximal inhibitory concentration: > 100000 nM
Compound 4: no number, only a limit; the forecaster's own chance of this, stated with the estimate: 45%; at least 1.6-fold (0.22 log units) between middle value and limit.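

Compound 3 and compound 4 both sit at a limit of the assay, so no step can be read between them: the limit of > 100000 nM in this assay, at which 3 of the 4 values shown sit.

The compounds shown leave open whether this methyl in place of hydrogen changes the number in this assay at all on the core of compound 3.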